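Exchanging bromine for chlorine: what to expect for compound 4

This account rests on a few compounds, and the source may have more. Where it says the series, first, only, none or still open, it means among the compounds named here.

In a functional assay on HepG2 cells (Homo sapiens) for antiproliferative activity, read by MTT assay, with a stated time of 72 h (on this read-out lower numbers stand for stronger inhibition and higher numbers for weaker inhibition), compound 1 (`O=C1NC(O)(CCn2cnc3cc[nH]c3c2=O)C(OCc2ccccc2)=C1OCc1ccccc1`) gives > 100000 nM as a limit of the assay and not a number. Compound 2 (`O=C1NC(O)(/C=C\n2cc(I)c3c(Cl)ncnc32)C(OCc2ccccc2)=C1OCc1ccccc1`) gives 32400 nM in this assay as a true number. Compound 3 (`O=C1NC(O)(CCn2cnc3cncc(Br)c32)C(OCc2ccccc2)=C1OCc1ccccc1`) gives 66500 nM and so holds the higher of the two true numbers, with compound 2 lower by a margin beyond the scatter.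

Compound 4 (`O=C1NC(O)(CCn2cnc3ccnc(Cl)c32)C(OCc2ccccc2)=C1OCc1ccccc1`) is still unmeasured, and its difference from compound 3 is a single exchange (a group of 10 heavy atoms (6 carbon, 3 nitrogen, 1 chlorine; one five-membered aromatic ring with 2 hetero atoms, one six-membered aromatic ring with 1 hetero atom) in place of a group of 10 heavy atoms (6 carbon, 3 nitrogen, 1 bromine; one five-membered aromatic ring with 2 hetero atoms, one six-membered aromatic ring with 1 hetero atom), on a saturated chain carbon, two bonds along the chain from a saturated ring carbon) in which a group carrying bromine leaves and a group carrying chlorine enters on a saturated chain carbon.

For the measured compounds named here, one measured step bears on this exchange: an at least 1.5-fold lower number from compound 1 to compound 3 (0.17 log units; that floor lies within the scatter) is the only comparison available. It starts from the limit of > 100000 nM in this assay, at which 1 of the 3 values shown sits, and so gives no exact size. Going by the values given here, no measured step exchanges bromine for chlorine, which leaves the value of compound 3 at 66500 nM as the anchor for the expectation.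

The expected step is a 1.1-fold lower number from compound 3 to compound 4 (0.04 log units; within the scatter) in this assay and no change beyond the scatter is expected. For compound 4 the estimated value is 60000 nM within an expected range of 30000 nM to 100000 nM in this assay for now.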

Compound 4, half-maximal inhibitory concentration: > 100000 nM
Compound 4 gave a limit, no number (the forecaster's own chance of this, stated with the estimate: 20%); at least 1.6-fold (0.22 log units) between middle value and limit.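

On the saturated chain carbon, two bonds along the chain from a saturated ring carbon, the group carrying chlorine in place of the group carrying bromine gives an at least 1.5-fold higher number from compound 3 to compound 4 (0.17 log units; that floor lies within the scatter). For the compounds shown here, this is the first measured exchange of these two groups, and it shows no gain for the group carrying chlorine, although the size of the step stays open and its floor does not clear the scatter. Compound 3 is thus the only one of compounds 1, 3 and 4 with a true number, and the step from compound 1 to compound 4 cannot be read, as both values are limits of the assay and not numbers: the limit of > 100000 nM in this assay, at which 2 of the 4 values shown sit.

The compounds shown leave open how far the true value of compound 4 lies from that of compound 3, and so whether the exchange matters at all beyond the scatter. They also leave open whether a group carrying fluorine or an amine in place of the halogen, or a longer chain to the same ring carbon, would bring a lower number in this assay.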